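Compound 4 against the limit of compound 3

A few compounds are considered here, and "the series" means these few. Any claim that something is new, unique, unknown or untested is made for them only; others in the source may bear on it.

Compound 1 `N#CSc1cn([C@H]2C[C@H](O)[C@@H](CO)O2)c(=O)[nH]c1=O`: 78900 nM
Compound 2 `O=c1[nH]c(=O)n([C@H]2C[C@H](O)[C@@H](CO)O2)cc1C#CCCO`: > 200000 nM (a limit)
Compound 3 `C[S+]([O-])c1cn([C@H]2C[C@H](O)[C@@H](CO)O2)c(=O)[nH]c1=O`: > 200000 nM (a limit)

All three results come from an ADME assay on L1210/0 cells (Mus musculus) for cytotoxicity, with a stated time of 48 h; a higher number here means a weaker inhibitor, a lower number a stronger inhibitor. Compound 3 gives no number, only a limit, and stands at the limit of > 200000 nM in this assay, at which 2 of the 3 values shown sit.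

The next compound is compound 4 `O=c1[nH]c(=O)n([C@H]2C[C@H](O)[C@@H](CO)O2)cc1C#Cc1ccccc1`, and the change is a group of 8 heavy atoms (8 carbon; one six-membered aromatic ring of carbon only) in place of a group of 3 heavy atoms (1 carbon, 1 oxygen, 1 sulfur; no ring), on an aromatic carbon. The group of 3 heavy atoms on the aromatic carbon gives way to 2-phenylethynyl, which holds a triple bond outside aromatic rings.

Among the compounds with values here, two measured steps bear on this. Replacing cyanosulfanyl with 4-hydroxybut-1-yn-1-yl gave an at least 2.5-fold higher number from compound 1 to compound 2 (0.40 log units; beyond the scatter). Replacing cyanosulfanyl with the group that compound 3 carries gave an at least 2.5-fold higher number from compound 1 to compound 3 (0.40 log units; beyond the scatter). Both are beyond the scatter, and both end at a limit, so only compound 1 has a true number. The step that the two limits leave unreadable from compound 2 to compound 3 tells nothing about size.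

Compound 2, the measured compound whose group also holds a triple bond, reaches only the limit > 200000 nM. Compound 4 is therefore expected to sit close to that limit, perhaps reported only as one. The expected change is an at least 1.3-fold lower number from compound 3 to compound 4 (0.12 log units; that floor lies within the scatter), which means no step beyond the scatter is expected in either direction. The estimated value for compound 4 is 150000 nM, with an expected range of 60000 nM to 300000 nM.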

Compound 4, half-maximal inhibitory concentration: > 200000 nM
Compound 4 was reported as a limit (the forecaster's own chance of this, stated with the estimate: 60%); at least 1.3-fold (0.12 log units) between middle value and limit.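

Putting 2-phenylethynyl in place of cyanosulfanyl on this aromatic carbon gave an at least 2.5-fold higher number from compound 1 to compound 4 (0.40 log units; beyond the scatter), so in this assay a six-membered aromatic ring of carbon only, carried on the triple bond, yields no measurable value, just as the 2-hydroxyethyl end of the triple bond in compound 2 yielded none. Within the data shown here, with compound 4, a second group with a triple bond outside aromatic rings stands at the limit, alongside compound 2 and compound 3, and compound 1 remains the only compound with a true number: the limit of > 200000 nM in this assay, at which 3 of the 4 values shown sit. The steps from compound 2 and from compound 3 to compound 4 run between two limits and cannot be read.

The compounds shown therefore leave open how compound 2, compound 3 and compound 4 truly rank against one another, and whether anything other than cyanosulfanyl at this aromatic carbon gives a number in this assay. As far as these compounds go, it also remains open whether a primary amine or a carboxylic acid at the far end of the triple bond, or a methylsulfanyl group directly on the aromatic carbon, would give a true number in this assay.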